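Swapping 2,6-dichlorophenyl for 4-methoxyphenyl

This account rests on a few compounds, and the source may have more. Where it says the series, first, only, none or still open, it means among the compounds named here.

Among the measured compounds shown here, only two compounds have numbers so far. For the measured compounds named here, in a functional assay on L1210 cells (Mus musculus) for inhibition (a lower number here means a stronger inhibitor, a higher number a weaker inhibitor), compound 1 `C/C(=C\COc1c(Cl)cccc1Cl)CC/C=C(\C)C1CC(=O)C(C)(C)O1` gives 58 ug/mL and compound 2 `C/C(=C\COc1c(Cl)cccc1Cl)CC/C=C(\C)C1=CC(=O)C(C)(C)O1` gives 30.7 ug/mL, which places compound 2 within the scatter of its only neighbour. The next molecule, compound 3 `COc1ccc(OC/C=C(\C)CC/C=C(\C)C2=CC(=O)C(C)(C)O2)cc1`, keeps the rest of compound 2 and changes one group: 4-methoxyphenyl in place of 2,6-dichlorophenyl on an oxygen on a saturated carbon. Put simply, 4-methoxyphenyl sits in place of 2,6-dichlorophenyl on an oxygen on a saturated carbon. Going by the values given here, the single measured step, a 1.9-fold lower number from compound 1 to compound 2 (0.28 log units; within the scatter), leaves the 2,6-dichlorophenyl group untouched, so it offers only weak guidance. Among the compounds with values here, no measurement yet shows what replacing that group does, and the data give no direction. The expected change is therefore none beyond the scatter, a 1.0-fold lower number from compound 2 to compound 3 (0.01 log units; within the scatter). For compound 3 the estimated value in this assay is 30 ug/mL, with an expected range from 11 ug/mL to 80 ug/mL.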

Compound 3, half-maximal inhibitory concentration: 40.2 ug/mL
Compound 3: middle estimate off by 1.3-fold (0.13 log units), on the low side; low and high end bracket the measured number.
By their numbers in this assay, from the lowest: compounds 2, 3 and 1 (each within the scatter of the next).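

Among the compounds shown here, this is the first change to the aromatic group on the oxygen, and in this assay replacing 2,6-dichlorophenyl with 4-methoxyphenyl gives a 1.3-fold higher number from compound 2 to compound 3 (0.12 log units; within the scatter). Although chlorine gives way to a methoxy group on the ring, this read-out does not separate the two groups, so this position accepts this exchange without a change beyond the scatter. No other measurement bears on why the two groups read alike.

As far as these compounds go, the swap keeps a six-membered aromatic ring of carbon only, so it remains open what a quite different group in that place, such as an amine, a carboxylic acid or a longer chain, would do to the number. From the compounds shown here alone, it also remains open whether the same exchange would read alike on the core of compound 1.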